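Swapping Isopropyl for Phenyl at the End of Compound 3

A few compounds are considered here, and "the series" means these few. Any claim that something is new, unique, unknown or untested is made for them only; others in the source may bear on it.

In a functional assay on MDA-MB-231 cells (Homo sapiens) for inhibition, read by MTT assay, with a stated time of 72 h (on this read-out lower numbers stand for stronger inhibition and higher numbers for weaker inhibition), compound 1 `CC(C)[C@H](NC(=O)c1cc(Cl)ccc1OCCN)C(=O)Nc1ccc([N+](=O)[O-])cc1Cl` gives > 10000 nM, which is a limit of the assay and not a number. Compound 2 `CC(C)[C@H](NC(=O)c1cc(Cl)ccc1OCCNC(=O)O)C(=O)Nc1ccc([N+](=O)[O-])cc1Cl` gives > 10000 nM, which is also a limit. Among the measured compounds shown here, compound 3 `CC(C)COC(=O)NCCOc1ccc(Cl)cc1C(=O)N[C@H](C(=O)Nc1ccc([N+](=O)[O-])cc1Cl)C(C)C` gives 4900 nM, the only actual number so far.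

Compound 4 `CC(C)[C@H](NC(=O)c1cc(Cl)ccc1OCCNC(=O)OCc1ccccc1)C(=O)Nc1ccc([N+](=O)[O-])cc1Cl` keeps the shared core and alters one chain end: phenyl in place of isopropyl on a saturated chain carbon bound to an oxygen next to a carbonyl group. Isobutoxycarbonyl thus becomes benzyloxycarbonyl.

For the measured compounds named here, two measured steps bear on this, an at least 2.0-fold lower number from compound 1 to compound 3 (0.30 log units; that floor lies within the scatter) and an at least 2.0-fold lower number from compound 2 to compound 3 (0.30 log units; that floor lies within the scatter). Both are floors within the scatter, and neither swaps the isopropyl end. No shift beyond the scatter is therefore expected, and the estimated step is a 1.2-fold lower number from compound 3 to compound 4 (0.09 log units; within the scatter). For compound 4 the expected value is 4000 nM, within an estimated range of 1500 nM to 10000 nM.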

Compound 4, half-maximal inhibitory concentration: > 10000 nM
Compound 4: a limit, no number (the forecaster's own chance of this, stated with the estimate: 25%); middle value at least 2.5-fold (0.39 log units) away from the limit.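

In this assay, among the compounds shown here, phenyl in place of isopropyl at this chain end gives an at least 2.0-fold higher number from compound 3 to compound 4 (0.30 log units; that floor lies within the scatter), so this is the first evidence on the end group itself, and the larger ring does not keep a measurable number. Going by these compounds, compound 4 gives only a limit of the assay and not a number, so the true size of the step stays unknown: the limit of > 10000 nM in this assay, at which 3 of the 4 values shown sit. The steps from compound 1 and compound 2 to compound 4 cannot be read.

On these data alone, whether a shorter ethyl end or a longer chain at this place would give a measurable number remains open.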